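Coumarin dithiolane amides: swapping the ester for phenyl

A few compounds are considered here, and "the series" means these few. Any claim that something is new, unique, unknown or untested is made for them only; others in the source may bear on it.

Measured compounds:
compound 1, `CC(=O)c1cc2ccc(OCCCn3cc(CNC(=O)CCCCC4CCSS4)nn3)cc2oc1=O`, 38%
compound 2, `CCOC(=O)c1cc2ccc(OCCCn3cc(CNC(=O)CCCCC4CCSS4)nn3)cc2oc1=O`, 36.1%

In a functional assay on PC-12 cells (Rattus norvegicus) for cytotoxicity, read by MTT assay, with stated times of 3 h and 2 h, tested at 10 uM (on this read-out higher numbers stand for a stronger effect at the one concentration tested and lower numbers for a weaker effect), compound 1 gives 38% and compound 2 gives 36.1%. Compound 2 holds the lowest of the two numbers, but the step of a number 1.9 percentage points lower from compound 1 to compound 2 (within the scatter) is within the scatter, so the two compounds cannot be told apart on this read-out. Compound 3, `O=C(CCCCC1CCSS1)NCc1cn(CCCOc2ccc3cc(-c4ccccc4)c(=O)oc3c2)nn1`, is not yet measured. It differs from compound 2 in one place: phenyl in place of ethoxycarbonyl on an aromatic carbon. Among the measured compounds shown here, the only measured step, a number 1.9 percentage points lower from compound 1 to compound 2 (within the scatter), changed a group on a carbonyl carbon rather than replacing the whole ethoxycarbonyl, so no measured step bears directly on this change. With nothing to point in either direction, the step from compound 2 to compound 3 is expected to be small, a number 0.1 percentage points lower from compound 2 to compound 3 (within the scatter). Compound 3 is therefore estimated at 36%, with a range from 20% to 52%.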

Compound 3, a percentage reported as activity, at one concentration (the size of the read-out at that concentration, not a potency): 29.1%
Beside the measured number, compound 3's estimate is 6.9 percentage points above it, and the stated range covers the measured number.
By their numbers in this assay, from the lowest: compounds 3, 2 and 1 (each within the scatter of the next).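

In this assay, the aromatic carbon two atoms from the ring oxygen now carries a phenyl ring, a group with no carbonyl and no hydrogen-bond acceptors, yet both steps stay within the scatter: a number 7 percentage points lower from compound 2 to compound 3 (within the scatter) and a number 8.9 percentage points lower from compound 1 to compound 3 (within the scatter). Among these three compounds, then, a carbonyl-bearing group on this carbon is not needed for a number in this range, and swapping ethoxycarbonyl or acetyl for phenyl gives no change that can be told from the scatter. Nothing available explains this result.

On these data alone, whether an amine or a carboxylic acid on this carbon would move the number beyond the scatter remains open. Each compound also has a reading at only one concentration, so the compounds shown leave their potency open.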